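A few compounds are considered here, and "the series" means these few. Any claim that something is new, unique, unknown or untested is made for them only; others in the source may bear on it.

Measured compounds and their values:

- Compound 1, `Cc1cc(C)c2cccc(OCc3c(Cl)ccc(S(=O)(=O)NC4(C(=O)N5CCN(C(=O)[C@H](CCCCN(C)C)N(C)C)CC5)CCCC4)c3Cl)c2n1`: < 10000 nM
- Compound 2, `Cc1cc(C)c2cccc(OCc3c(Cl)ccc(S(=O)(=O)NC4(C(=O)N5CCN(C(=O)CCCCC[N+](C)(C)C)CC5)CCCC4)c3Cl)c2n1`: < 10000 nM

In an assay on isolated protein for binding affinity to B1 bradykinin receptor (Homo sapiens) (on this read-out lower numbers stand for stronger inhibition and higher numbers for weaker inhibition), compound 1 gives < 10000 nM, which is a limit of the assay rather than a number. Compound 2 also gives < 10000 nM, again a limit. Both values therefore sit at the limit of < 10000 nM in this assay, at which 2 of the 2 values shown sit, so nothing can be read about where either compound truly stands, and the step that the two limits leave unreadable from compound 1 to compound 2 cannot be sized.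

Compound 3, `Cc1cc(C)c2cccc(OCc3c(Cl)ccc(S(=O)(=O)NC4(C(=O)N5CCN(C(=O)[C@H](CCCCN)[N+](C)(C)C)CC5)CCCC4)c3Cl)c2n1`, differs from compound 1 by a group of 10 heavy atoms (8 carbon, 2 nitrogen; no ring) in place of a group of 11 heavy atoms (9 carbon, 2 nitrogen; no ring), on a carbonyl carbon: the 1,5-bis(dimethylamino)pentyl group leaves, and a group with a net charge of plus one and one hydrogen-bond donor enters, on the carbonyl carbon whose other neighbour is an amide-type nitrogen in a ring. Among the compounds with values here, no measured step reports a readable size, so the only guide is that the two known compounds both fall within the same limit. Compound 3 is therefore expected to land in this assay around 1500 nM, within a wide range from 100 nM to 10000 nM, a step that the limit leaves unreadable from compound 1 to compound 3 that is estimated, not measured.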

Compound 3, inhibition constant: < 10000 nM
Compound 3 was reported as a limit; the forecaster's own chance of this, stated with the estimate: 55%; the middle value is on the limit's open side.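

In this assay compound 3 gives < 10000 nM as a limit and not a number. Within the data shown here, no step among compound 1, compound 2 and compound 3 can be read, since all three share one limit: the limit of < 10000 nM in this assay, at which 3 of the 3 values shown sit.

As far as these compounds go, what stays open is where each of the three truly stands, and whether changing the group on the carbonyl carbon alters the read-out at all.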